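A few compounds are considered here, and "the series" means these few. Any claim that something is new, unique, unknown or untested is made for them only; others in the source may bear on it.

Series in an ADME assay on microsomes from liver (Canis lupus familiaris) for metabolic stability; a higher number here means that the compound lasts longer, a lower number that the compound disappears faster:
Compound 1 `Nc1nc(NCCNc2ncc(-c3ncc[nH]3)c(-c3ccc(Cl)cc3)n2)ccc1[N+](=O)[O-]`: > 0.5 h, a limit.
Compound 2 `Nc1nc(NCCNc2ncc(-c3ncc[nH]3)c(-c3ccccc3Cl)n2)ccc1[N+](=O)[O-]`: > 0.5 h, a limit.
Compound 3 `Nc1nc(NCCNc2ncc(-c3ncc[nH]3)c(-c3cc(F)c(F)cc3F)n2)ccc1[N+](=O)[O-]`: > 0.5 h, a limit.

Compound 3 has only a limit and no number, > 0.5 h. The series as a whole shows (the limit of > 0.5 h in this assay, at which 3 of the 3 values shown sit).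

Compound 4 `Nc1nc(NCCNc2ncc(-c3ncc[nH]3)c(-c3ccc(F)cc3Br)n2)ccc1[N+](=O)[O-]` carries 2-bromo-4-fluorophenyl in place of 2,4,5-trifluorophenyl on an aromatic carbon.

The relevant steps are a step that the two limits leave unreadable from compound 1 to compound 2, a step that the two limits leave unreadable from compound 1 to compound 3 and a step that the two limits leave unreadable from compound 2 to compound 3. None has a readable size, so they give no sign of any direction. The expected change in this assay is therefore none beyond the scatter, as a step that the limit leaves unreadable from compound 3 to compound 4.

Compound 4 is estimated at 0.6 h, with an expected range of 0.3 h to 1.2 h.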

Compound 4, half-life: > 0.5 h
Compound 4: a limit, no number; the forecaster's own chance of this, stated with the estimate: 80%; the middle value does not contradict the limit.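

Within the data shown here, compound 4 sits at a limit, as do compound 1, compound 2 and compound 3, so no step among them can be read. The compounds shown leave open how long each lasts in this assay, and whether changing the substituted phenyl group alters that at all: the limit of > 0.5 h in this assay, at which 4 of the 4 values shown sit.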